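Two Chlorines Traded for One Iodine on the Aryl Ring

The source may report more compounds than this note shows. Statements on the series, on what has been measured and on what is new or still open speak of the compounds shown alone.

Compound 3 `COC(=O)C1=C(C)N=C(C)/C(=C(\O)OC)C1c1cc(Cl)cc(Cl)c1` gives 93.3 nM in a functional assay (muscle tissue) with Cavia porcellus as the target (a lower number here means that less compound is needed, a higher number that more compound is needed for the effect), the second highest of the three numbers at hand. Its nearest neighbour, compound 1 `COC(=O)C1=C(C)N=C(C)/C(=C(\O)OC)C1c1c(Cl)cccc1Cl`, gives 1.91 nM, while the furthest, compound 2 `COC(=O)C1=C(C)N=C(C)/C(=C(\O)OC)C1c1cccc(OC(=O)c2ccccc2)c1`, gives 6310 nM. Compound 4 `COC(=O)C1=C(C)N=C(C)/C(=C(\O)OC)C1c1cccc(I)c1` differs from compound 3 in one place: 3-iodophenyl in place of 3,5-dichlorophenyl on a saturated ring carbon. Going by the values given here, the only measured step, a 49-fold higher number from compound 1 to compound 3 (1.69 log units; beyond the scatter), concerns where two chlorines sit on the ring and does not cover replacing them with a single iodine, so no step bears directly on this change. Among the compounds with values here, a single substituent at the 3-position is seen only in compound 2, whose number is far higher than that of compound 3. For compound 4 a modest step of a 1.6-fold lower number from compound 3 to compound 4 (0.19 log units; within the scatter) is expected. Compound 4 is therefore estimated at 60 nM, with a range from 10 nM to 400 nM.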

Compound 4, half-maximal effective concentration: 41.7 nM
Compound 4: middle estimate off by 1.4-fold (0.16 log units), on the high side; the range from low to high includes it.
By their numbers in this assay, from the lowest: compound 1; then compound 4; then compound 3; then compound 2.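

Replacing two chlorines with one iodine costs nothing in this assay; the number falls instead (a 2.2-fold lower number from compound 3 to compound 4 (0.35 log units; beyond the scatter)). The single substituent on the ring matters greatly, since iodo in place of benzoyloxy gives the largest step seen so far (a 150-fold lower number from compound 2 to compound 4 (2.18 log units; beyond the scatter)), yet 3-iodophenyl still does not match 2,6-dichlorophenyl (a 22-fold higher number from compound 1 to compound 4 (1.34 log units; beyond the scatter)). No measured evidence accounts for these steps. The compounds shown leave open whether the iodo group could be replaced by bromo, an amine or a carboxylic acid while keeping this number.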